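This account rests on a few compounds, and the source may have more. Where it says the series, first, only, none or still open, it means among the compounds named here.

The series is a set of aryl amides built on a shared core and tested in a functional assay on A549 cells (Homo sapiens) for cytotoxicity, read by MTT assay, with a stated time of 24 h; a lower number here means a stronger inhibitor, a higher number a weaker inhibitor. Compound 2 `Cc1cc(-c2nc3ccccc3o2)ccc1NC(=O)CN1CCN(CCN(C)C)CC1` gives 30500 nM, while compound 1 `Cc1cc(-c2nc3cc(Cl)ccc3o2)ccc1NC(=O)CN1CCN(CCN(C)C)CC1`, which carries the change (chloro in place of hydrogen on an aromatic carbon), gives 24400 nM; that step is a 1.3-fold lower number from compound 2 to compound 1 (0.10 log units; within the scatter). Compound 3 `CN(C)CCCN1CCN(CC(=O)Nc2ccc(-c3nc4ccccc4o3)cc2)CC1` has a core that differs from that of compound 2 in a way not broken down here, and in this assay compound 3 gives 18300 nM. Compound 4 `CN(C)CCCN1CCN(CC(=O)Nc2ccc(-c3nc4cc(Cl)ccc4o3)cc2)CC1` has not yet been measured; it differs from compound 3 by chloro in place of hydrogen on an aromatic carbon, at the same place as the earlier change. The step expected is a 1.2-fold lower number from compound 3 to compound 4 (0.09 log units; within the scatter), which rests on the earlier pair because a 1.3-fold lower number from compound 2 to compound 1 (0.10 log units; within the scatter) stayed within the scatter. Compound 4 is therefore expected to give 15000 nM, estimated to lie between 7000 nM and 32000 nM.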

Compound 4, half-maximal inhibitory concentration: 4320 nM
Compound 4: middle estimate off by 3.5-fold (0.54 log units), on the high side; measured number outside the range, below it.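

In this assay, chloro in place of hydrogen now gives a 4.2-fold lower number from compound 3 to compound 4 (0.63 log units; beyond the scatter), a step beyond the scatter. The change therefore does not carry from one core to the other with a single size: the same change on two cores in this assay, a 1.3-fold lower number (0.10 log units; within the scatter) from compound 2 to compound 1 and a 4.2-fold lower number (0.63 log units; beyond the scatter) from compound 3 to compound 4, 3.4-fold (0.53 log units) apart, beyond the scatter of two such steps. This shows that the size of the step differed between these two cores, but two pairs do not show which feature of the cores goes with that difference, or what the change would do on any other core.

The compounds shown leave open whether a bromo or methoxy group in place of the chloro would also give steps that differ between the two cores. They also leave open how a longer chain ending in the dimethylamino group would affect the step.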